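Furan-2-yl for Thiophen-3-yl Across Two Related Cores

A few compounds are considered here, and "the series" means these few. Any claim that something is new, unique, unknown or untested is made for them only; others in the source may bear on it.

Compound 1 `Oc1ccc(-c2cc(-c3ccccc3)cc(-c3ccsc3)n2)cc1`: 5700 nM
Compound 2 `Oc1ccc(-c2cc(-c3ccccc3)cc(-c3ccco3)n2)cc1`: 1400 nM
Compound 3 `Oc1cccc(-c2cc(-c3ccccc3)nc(-c3ccsc3)c2)c1`: 19000 nM

Three compounds have been run in a functional assay on MDA-MB-231 cells (Homo sapiens) for cytotoxicity, read by ELISA, with a stated time of 2 days; on this read-out lower numbers stand for stronger inhibition and higher numbers for weaker inhibition. Compound 1 and compound 2 share a core and differ in one place: furan-2-yl in place of thiophen-3-yl on an aromatic carbon. That change made a 4.1-fold lower number from compound 1 to compound 2 (0.61 log units; beyond the scatter). Compound 3 has the same atoms as compound 1, joined differently; the difference between the two cores is not broken down here. In this assay compound 3 gives the highest number of the three, and its gaps to the other two both lie beyond the scatter. Compound 1 gives 5700 nM and compound 2 gives 1400 nM.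

Compound 4 `Oc1cccc(-c2cc(-c3ccccc3)nc(-c3ccco3)c2)c1` has not yet been measured. It differs from compound 3 in one place: furan-2-yl in place of thiophen-3-yl on an aromatic carbon. This is the same kind of change as that from compound 1 to compound 2, though the surroundings are not identical: the place in compound 1 is meta to a 4-hydroxyphenyl group, whereas in compound 3 it is meta to a 3-hydroxyphenyl group. Going by the values given here, with only one prior instance of this change, the expectation for compound 4 rests on that step alone. Compound 4 is expected to show a 4.0-fold lower number from compound 3 to compound 4 (0.60 log units; beyond the scatter), a step similar in size to a 4.1-fold lower number from compound 1 to compound 2 (0.61 log units; beyond the scatter), because compound 3 starts from 19000 nM and the same kind of change lowered the number for compound 2 to 1400 nM. On this basis compound 4 is estimated at 4800 nM, with a range from 1800 nM to 13000 nM.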

Compound 4, half-maximal inhibitory concentration: 20800 nM
Compound 4: the middle estimate sits 4.3-fold (0.64 log units) below what was measured, and the stated range ends below it.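

In this assay, the swap of thiophen-3-yl for furan-2-yl did not carry over from one core to the other. On the core of compound 3 it gave a 1.1-fold higher number from compound 3 to compound 4 (0.04 log units; within the scatter), so the two numbers cannot be told apart, and this step does not match the one seen on the core of compound 1: the same change on two cores in this assay, a 4.1-fold lower number (0.61 log units; beyond the scatter) from compound 1 to compound 2 and a 1.1-fold higher number (0.04 log units; within the scatter) from compound 3 to compound 4, 4.5-fold (0.65 log units) apart, beyond the scatter of two such steps. This shows that the lower number seen with furan-2-yl on one core cannot be assumed on the other, but with a single pair on each core it does not show how the change would behave on any further core, and since the two cores hold the same atoms joined differently, the pairs do not say which part of that difference matters.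

The compounds shown leave open whether another five-membered ring, such as thiophen-2-yl or furan-3-yl, would follow the step on the core of compound 1 or the step on the core of compound 3. They also leave open how each core would respond if an amine or a carboxylic acid took the place of the hydroxyl group on the hydroxyphenyl ring.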